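Trifluoromethyl in place of chloro on a shared core

The compounds below may be only part of what the source reports. "The series", "measured", "known", "first", "only" and "open" are said of these compounds alone.

Among the measured compounds shown here, only two compounds have numbers so far. In a functional assay on V79 cells (Cricetulus griseus) for cytotoxicity, read by colony formation (a lower number here means a stronger inhibitor, a higher number a weaker inhibitor), compound 2 (`CC1CN(c2c(F)cc3c(=O)c(C(=O)O)cn(C4CC4)c3c2Cl)CC(C)N1`) gives 140 ug/mL, and compound 1 (`CC1(CN)CCN(c2c(F)cc3c(=O)c(C(=O)O)cn(C4CC4)c3c2C(F)(F)F)C1`) gives 110 ug/mL. These two values lie within the usual scatter of each other, so compound 2 cannot be separated from compound 1 on this evidence.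

The next compound is compound 3 (`CC1CN(c2c(F)cc3c(=O)c(C(=O)O)cn(C4CC4)c3c2C(F)(F)F)CC(C)N1`), which has trifluoromethyl in place of chloro on an aromatic carbon of compound 2: trifluoromethyl in place of chloro on an aromatic carbon. The 3,5-dimethylpiperazin-1-yl group stays as it is.

For the measured compounds named here, no pair of measured compounds differs in one place, so no direct precedent exists for this change. Going by the values given here, the only hint is compound 1, which already carries trifluoromethyl, though with a different group where compound 2 has its 3,5-dimethylpiperazin-1-yl group, and compound 1 gives 110 ug/mL. The expected step is therefore none beyond the scatter, estimated as a 1.2-fold lower number from compound 2 to compound 3 (0.07 log units; within the scatter). For compound 3 the estimated value in this assay is 120 ug/mL, with an expected range of 60 ug/mL to 240 ug/mL.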

Compound 3, half-maximal inhibitory concentration: > 500 ug/mL
Compound 3 gave a limit, no number; the forecaster's own chance of this, stated with the estimate: 10%; middle value at least 4.1-fold (0.61 log units) from the limit.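

In this assay compound 3 gives a limit of the assay and not a number, so both new steps have a floor but no known size: the limit of > 500 ug/mL in this assay, at which 1 of the 3 values shown sits. Among the compounds shown here, with the 3,5-dimethylpiperazin-1-yl group held fixed, trifluoromethyl in place of chloro gives an at least 3.5-fold higher number from compound 2 to compound 3 (0.55 log units; beyond the scatter), and since a higher number means a weaker inhibitor, this is the first sign that the group on this aromatic carbon matters here. With trifluoromethyl held fixed, 3,5-dimethylpiperazin-1-yl in place of 3-(aminomethyl)-3-methylpyrrolidin-1-yl gives an at least 4.5-fold higher number from compound 1 to compound 3 (0.65 log units; beyond the scatter), so trifluoromethyl alone does not settle the outcome and the other group on the ring counts as well.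

The compounds shown leave open whether the step from chloro to trifluoromethyl would be as large with 3-(aminomethyl)-3-methylpyrrolidin-1-yl in place of the 3,5-dimethylpiperazin-1-yl group, as the evidence rests on a single pair. They also leave open where a methyl or a methoxy group on this same aromatic carbon would fall relative to chloro and trifluoromethyl.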